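Benzyl substitution: from compound 3 to compound 4

This account rests on a few compounds, and the source may have more. Where it says the series, first, only, none or still open, it means among the compounds named here.

compound 1 `COc1ccc(CN(C(=O)CSc2nc3ccccc3s2)c2cc(OC)c(OC)c(OC)c2)cc1O` gives 35 nM
compound 2 `COc1cc(CN(C(=O)CSc2nc3ccccc3s2)c2cc(OC)c(OC)c(OC)c2)cc(OC)c1OC` gives 45700 nM
compound 3 `COc1cc(N(Cc2ccccc2)C(=O)CSc2nc3ccccc3s2)cc(OC)c1OC` gives 44300 nM

In a functional assay on MGC-803 cells (Homo sapiens) for antiproliferative activity, read by MTT assay, with a stated time of 48 h (a higher number here means a weaker inhibitor, a lower number a stronger inhibitor), compound 3 sits level with compound 2 (a 1.0-fold lower number from compound 2 to compound 3 (0.01 log units; within the scatter)), and neither comes near compound 1. The change to compound 4 `COc1ccc(CN(C(=O)CSc2nc3ccccc3s2)c2cc(OC)c(OC)c(OC)c2)cc1N` is 3-amino-4-methoxyphenyl in place of phenyl on a saturated chain carbon bound to an amide-type nitrogen. Substitution as such guarantees nothing, since compound 2 carries 3,4,5-trimethoxyphenyl without any gain. The steps that matter are a 1300-fold higher number from compound 1 to compound 3 (3.10 log units; beyond the scatter) and a 1300-fold higher number from compound 1 to compound 2 (3.12 log units; beyond the scatter), both large and both setting apart the 3-hydroxy-4-methoxyphenyl of compound 1. The entering group keeps the 4-methoxy and has amino for hydroxy, a swap untested here. A large drop in the number is therefore expected, probably short of the full gap. The expected change is a 370-fold lower number from compound 3 to compound 4 (2.57 log units; beyond the scatter) in this assay. Compound 4 is estimated at 120 nM (range 20 nM to 3000 nM).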

Compound 4, half-maximal inhibitory concentration: 84 nM
Beside the measured number, compound 4's estimate is 1.4-fold (0.15 log units) above it, and the stated range covers the measured number.
By their numbers in this assay, from the lowest: compound 1; then compound 4; then compounds 3 and 2 (each within the scatter of the next).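

In this assay a second substituted benzyl now stands apart from the phenyl and 3,4,5-trimethoxyphenyl compounds, with a 530-fold lower number from compound 3 to compound 4 (2.72 log units; beyond the scatter) and a 540-fold lower number from compound 2 to compound 4 (2.74 log units; beyond the scatter) as the steps, so the large gain does not depend on the hydroxy group alone. Amino in place of hydroxy costs little by comparison, with a 2.4-fold higher number from compound 1 to compound 4 (0.38 log units; beyond the scatter) as a modest step that still lies beyond the scatter. Nothing available explains what either group does at this position.

Going by these compounds, whether the gain needs both substituents remains open: a 3-aminophenyl or a 4-methoxyphenyl group would separate them. Also open, on these data alone, is whether the amino can be replaced by a dimethylamino or acetamido group.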